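Nitro in Place of Methyl on a Weakly Active Core

A few compounds are considered here, and "the series" means these few. Any claim that something is new, unique, unknown or untested is made for them only; others in the source may bear on it.

Compound 1, `CC1(C)[C@@H]2CC[C@@]1(CS(=O)(=O)N1CCN(c3cc(C(F)(F)F)ccn3)CC1)C(=O)C2`, gives 25100 nM in a functional assay on CHO-K1 cells for antagonist activity at C-X-C chemokine receptor type 3 (Homo sapiens), read by FLIPR and calcium flux; a higher number here means a weaker inhibitor, a lower number a stronger inhibitor.
Compound 2, `CC1(C)[C@@H]2CC[C@@]1(CS(=O)(=O)N1CCN(c3ccccn3)CC1)C(=O)C2`, gives > 31600 nM in this assay, a limit rather than a number.
Compound 3, `Cc1ccc(N2CCN(S(=O)(=O)C[C@]34CC[C@H](CC3=O)C4(C)C)CC2)nc1`, gives > 31600 nM in this assay, again a limit rather than a number.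

Compound 3 therefore stands at the edge of what this assay reports, and compound 2 sits there with it; this is the situation described by the limit of > 31600 nM in this assay, at which 2 of the 3 values shown sit. Compound 1 is the only one of the three with a number. The steps from it read an at least 1.2-fold higher number from compound 1 to compound 2 (0.10 log units; that floor lies within the scatter) and an at least 1.2-fold higher number from compound 1 to compound 3 (0.10 log units; that floor lies within the scatter), both with a floor that lies within the scatter, while the step that the two limits leave unreadable from compound 2 to compound 3 cannot be read from two limits.

Compound 4, `CC1(C)[C@@H]2CC[C@@]1(CS(=O)(=O)N1CCN(c3ccc([N+](=O)[O-])cn3)CC1)C(=O)C2`, differs from compound 3 by nitro in place of methyl on an aromatic carbon. Among the compounds with values here, no measured step touches a nitro group, and the measured steps that exist are small or unreadable, so no direction can be drawn from them. Compound 4 is expected to stay close to where compound 3 stands, with an at least 1.0-fold lower number from compound 3 to compound 4 (0.02 log units; that floor lies within the scatter) not beyond the scatter. The estimate for compound 4 in this assay is 30000 nM, within 10000 nM to 100000 nM.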

Compound 4, half-maximal inhibitory concentration: > 31600 nM
Compound 4: no number, only a limit (the forecaster's own chance of this, stated with the estimate: 55%); middle value at least 1.0-fold (0.02 log units) away from the limit.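

With nitro on this aromatic carbon, two atoms from the ring nitrogen and para to a large group, compound 4 also gives only a limit in this assay, so hydrogen, methyl and nitro at this position all end in a limit and the steps among compounds 2, 3 and 4 cannot be read. Within the data shown here, the one step that can be read is an at least 1.2-fold higher number from compound 1 to compound 4 (0.10 log units; that floor lies within the scatter), so it sets no order between the 5-nitropyridin-2-yl and 4-(trifluoromethyl)pyridin-2-yl groups. Limits now make up most of what is shown: the limit of > 31600 nM in this assay, at which 3 of the 4 values shown sit.

As far as these compounds go, how far hydrogen, methyl and nitro lie apart at this position stays open. Also open, from the compounds shown here alone, is whether an amine or a carboxylic acid there, on the shared core, would give a number instead of a limit.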